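Bromo to Methoxy on an Inactive Core

This account rests on a few compounds, and the source may have more. Where it says the series, first, only, none or still open, it means among the compounds named here.

Compound 1 `CCOC(=O)C12C(=O)OCC=C1COC2c1ccccc1` is the parent of a small set tested in a functional assay on A549 cells (Homo sapiens) for cytotoxicity, read by MTT assay; a higher number here means a weaker inhibitor, a lower number a stronger inhibitor. In this assay compound 1 gives only an assay limit of > 1000000 nM. Compound 2 `CCOC(=O)C12C(=O)OCC=C1COC2c1ccccc1F` in this assay likewise gives only a limit of > 1000000 nM. Compound 3 `CCOC(=O)C12C(=O)OCC=C1COC2c1ccc(Br)cc1` in this assay also gives only a limit of > 1000000 nM. The steps a step that the two limits leave unreadable from compound 1 to compound 2, a step that the two limits leave unreadable from compound 1 to compound 3 and a step that the two limits leave unreadable from compound 2 to compound 3 cannot be sized, since all three values sit at the limit of > 1000000 nM in this assay, at which 3 of the 3 values shown sit. Compound 3 therefore stands with the others at that limit. Compound 4 `CCOC(=O)C12C(=O)OCC=C1COC2c1ccc(OC)cc1` differs by methoxy in place of bromo on an aromatic carbon. Within the data shown here, no measured step bears on this change, and no step beyond the scatter is expected in this assay. Compound 4 is expected to give 1000000 nM, with a range from 300000 nM to 3000000 nM. The step of a number no higher from compound 3 to compound 4 (the limit leaves the size open) is thus estimated to stay within the scatter.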

Compound 4, half-maximal inhibitory concentration: 9300 nM
Compound 4: middle estimate off by 110-fold (2.03 log units), on the high side, and the stated range ends above it.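

In this assay, the aromatic carbon that carries bromo in compound 3 proves sensitive to what sits there: methoxy gives an at least 100-fold lower number from compound 3 to compound 4 (2.03 log units; beyond the scatter), and measured against the unsubstituted parent it gives an at least 100-fold lower number from compound 1 to compound 4 (2.03 log units; beyond the scatter). The shared core can therefore show cytotoxicity, and a single group decides whether it does here. Compound 4 alone has left the limit that holds the others: the limit of > 1000000 nM in this assay, at which 3 of the 4 values shown sit.

As far as these compounds go, whether hydroxy or ethoxy on this carbon would give a similar number stays open. So does whether methoxy on another carbon of the ring would.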